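Replacing 4-chlorophenyl with 5-methylthiophen-2-yl in a growth inhibitor series

The source may report more compounds than this note shows. Statements on the series, on what has been measured and on what is new or still open speak of the compounds shown alone.

In a functional assay on DU-145 cells (Homo sapiens) for inhibition, read by trypan blue exclusion, with a stated time of 96 h (a lower number here means a stronger inhibitor of growth, a higher number a weaker inhibitor of growth), compound 1 `CSc1ccc(/C=C(\C(=O)c2ccc(Cl)cc2)S(=O)(=O)Cc2ccc(C)cc2)cc1` gives 10000 nM, and compound 3 `Cc1ccc(CS(=O)(=O)/C(=C/c2ccc(Cl)cc2)C(=O)c2ccc(Cl)cc2)cc1` gives 25000 nM. Compound 2 `Cc1ccc(CS(=O)(=O)/C(=C/c2c(O)cc(O)cc2O)C(=O)c2ccc(Cl)cc2)cc1` gives > 100000 nM, which is a limit of the assay and not a number. Compound 3 therefore has the higher of the two true numbers, making it the weaker of that pair.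

Compound 4 `Cc1ccc(CS(=O)(=O)/C(=C/c2ccc(C)s2)C(=O)c2ccc(Cl)cc2)cc1` is still unmeasured. It keeps the rest of compound 3 and changes one group on a double-bonded chain carbon bound to a double-bonded chain carbon: 5-methylthiophen-2-yl in place of 4-chlorophenyl on a double-bonded chain carbon bound to a double-bonded chain carbon.

The three measured compounds differ in the aromatic group at this same place, so their steps offer a guide. Putting chloro in place of methylsulfanyl gave a 2.5-fold higher number from compound 1 to compound 3 (0.40 log units; beyond the scatter), a modest step. Putting 4-chlorophenyl in place of 2,4,6-trihydroxyphenyl gave an at least 4.0-fold lower number from compound 2 to compound 3 (0.60 log units; beyond the scatter). From the compounds shown here alone, the true size of this step is unknown because compound 2 gives > 100000 nM, which is a limit.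

Neither step tests a 5-methylthiophen-2-yl group directly. The modest size of a 2.5-fold higher number from compound 1 to compound 3 (0.40 log units; beyond the scatter) points to a small change, with no firm direction. The expected change is a 1.3-fold lower number from compound 3 to compound 4 (0.10 log units; within the scatter), which would not stand beyond the scatter. For compound 4 the estimated value is 20000 nM, with an expected range of 7000 nM to 60000 nM.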

Compound 4, concentration for 50% growth inhibition: 25000 nM
Compound 4: middle estimate off by 1.3-fold (0.10 log units), on the low side, within the range that was stated.
By their numbers in this assay, from the lowest: compound 1; then compounds 3 and 4 (each within the scatter of the next). At a limit, above all of these: compound 2.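

In this assay, exchanging a six-membered aromatic ring of carbon only for a five-membered one with a sulfur atom gives no change at the digits printed from compound 3 to compound 4 (within the scatter), so at this position 5-methylthiophen-2-yl and 4-chlorophenyl cannot be told apart, and among these compounds the ring need not be six-membered to give this level of growth inhibition. The new group does not reach the 4-(methylsulfanyl)phenyl group, with a 2.5-fold higher number from compound 1 to compound 4 (0.40 log units; beyond the scatter), while it clearly outperforms the 2,4,6-trihydroxyphenyl group, with an at least 4.0-fold lower number from compound 2 to compound 4 (0.60 log units; beyond the scatter). Compound 2 is read at a limit and not a number, so the true size of its step stays unknown: the limit of > 100000 nM in this assay, at which 1 of the 4 values shown sits.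

The compounds shown do not separate the part played by the ring sulfur from that of the methyl group on the ring, so it remains open which of the two, if either, matters here. From the compounds shown here alone, it is also open whether a furan-2-yl or pyridin-2-yl ring, or a thiophene carrying an amine or a carboxylic acid in place of the methyl, would leave the number where it stands or move it toward that of compound 1.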